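Longer ester chains on a shared core: compound 3 expected

The compounds below may be only part of what the source reports. "The series", "measured", "known", "first", "only" and "open" are said of these compounds alone.

Compound 1, `CCCCCOC(=O)CCC(=O)N1CCN(CCCOc2cc3c(Nc4ccc(F)c(Cl)c4)ncnc3cc2OC)CC1`, gives 18.2% in a functional assay on A549 cells (Homo sapiens) for cytotoxicity, read by MTT assay, with a stated time of 24 h, tested at 80 uM; on this read-out higher numbers stand for a weaker effect at the one concentration tested and lower numbers for a stronger effect.
Compound 2, `CCCCCCCCCCCCCCOC(=O)CCC(=O)N1CCN(CCCOc2cc3c(Nc4ccc(F)c(Cl)c4)ncnc3cc2OC)CC1`, gives 77.2% in this assay.

Compound 2 stands highest of the two numbers in this assay, with compound 1 the nearest and a good deal lower. Among the measured compounds shown here, the only measured step is a number 59 percentage points higher from compound 1 to compound 2 (beyond the scatter), which is the change nonyl in place of hydrogen on a saturated chain carbon, five bonds along the chain from an oxygen next to a carbonyl group.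

Compound 3, `CCCCCCCCCCCCCCCCOC(=O)CCC(=O)N1CCN(CCCOc2cc3c(Nc4ccc(F)c(Cl)c4)ncnc3cc2OC)CC1`, has not yet been measured. Its difference from compound 2 is ethyl in place of hydrogen on a saturated chain carbon, ten or more bonds along the chain from an oxygen next to a carbonyl group. This is a further extension of the same chain that was lengthened from compound 1 to compound 2, so that step bears on it directly, though the present addition is much shorter than the nonyl added there. Compound 3 is therefore expected to move in the same direction in this assay, by a number 6.8 percentage points higher from compound 2 to compound 3 (within the scatter), a smaller step than before and possibly within the scatter. Compound 3 is estimated to give 84%, within a range from 66% to 100%.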

Compound 3, a percentage reported as activity, at one concentration (the size of the read-out at that concentration, not a potency): 74.3%
For compound 3 the middle estimate is 9.7 percentage points above the measured one, within the range that was stated.
By their numbers in this assay, from the lowest: compound 1; then compounds 3 and 2 (each within the scatter of the next).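

In this assay, ethyl in place of hydrogen on a saturated chain carbon, ten or more bonds along the chain from an oxygen next to a carbonyl group, comes with a number 2.9 percentage points lower from compound 2 to compound 3 (within the scatter) and so the read-out does not separate the two esters at this far stretch of the chain. Measured against the shorter ester, the longer chain comes with a number 56.1 percentage points higher from compound 1 to compound 3 (beyond the scatter) and so the large step seen earlier also holds for this longer chain, while the further lengthening adds nothing that can be told from the scatter. Nothing available bears on why the read-out behaves this way along the chain.

The compounds shown leave open where the rise sets in for chains of length between those of compound 1 and compound 2, and whether a longer chain would read the same. They also leave open what a branched chain, an amine or a carboxylic acid would give in place of the ester chain.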